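A new side group on the shared core

A few compounds are considered here, and "the series" means these few. Any claim that something is new, unique, unknown or untested is made for them only; others in the source may bear on it.

Measured in a functional assay on MGC-803 cells (Homo sapiens) for antiproliferative activity, read by MTT assay, with a stated time of 48 h; a lower number here means a stronger inhibitor, a higher number a weaker inhibitor:
Compound 1 `COc1ccc(CN(C(=O)Cn2cc(COc3ccccc3)nn2)c2cc(OC)c(OC)c(OC)c2)cc1` gives 12500 nM
Compound 2 `COc1ccc(CN(C(=O)Cn2cc(CSc3nncs3)nn2)c2cc(OC)c(OC)c(OC)c2)cc1` gives 5000 nM
Compound 3 `COc1ccc(CN(C(=O)Cn2cc(CSc3nnnn3C)nn2)c2cc(OC)c(OC)c(OC)c2)cc1` gives 6570 nM

Compound 3 stands within the scatter of both other compounds (a 1.9-fold lower number from compound 1 to compound 3 (0.28 log units; within the scatter)) and (a 1.3-fold higher number from compound 2 to compound 3 (0.12 log units; within the scatter)). For the measured compounds named here, only one measured step goes beyond the scatter, and it is modest (a 2.5-fold lower number from compound 1 to compound 2 (0.40 log units; beyond the scatter)).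

Compound 4 `COc1ccc(CN(C(=O)Cn2cc(CNS(=O)(=O)c3ccc(Br)cc3)nn2)c2cc(OC)c(OC)c(OC)c2)cc1` has not yet been measured. It differs from compound 3 by ((4-bromophenyl)sulfonyl)amino in place of (1-methyl-1H-tetrazol-5-yl)sulfanyl on a saturated chain carbon bound to an aromatic carbon, with ((4-bromophenyl)sulfonyl)amino in place of (1-methyl-1H-tetrazol-5-yl)sulfanyl on a saturated chain carbon bound to an aromatic carbon. All three measured steps change this same group, but none introduces the entering group, so they offer only indirect guidance. Since the largest of them is small (a 2.5-fold lower number from compound 1 to compound 2 (0.40 log units; beyond the scatter)), no step beyond the scatter is expected in this assay, and the data favour neither direction. The expected step is small (a 1.1-fold lower number from compound 3 to compound 4 (0.04 log units; within the scatter)). Compound 4 is estimated at 6000 nM, with an expected range (from 1800 nM to 20000 nM).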

Compound 4, half-maximal inhibitory concentration: 430 nM
Estimate against measurement, compound 4: 14-fold (1.14 log units) above; measured number outside the range, below it.
By their numbers in this assay, from the lowest: compound 4; then compounds 2, 3 and 1 (each within the scatter of the next, the first and the last beyond it).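

In this assay, for the compounds shown here, the position on a saturated chain carbon bound to an aromatic carbon proves far more responsive than the earlier compounds showed: their exchanges among phenoxy and the two sulfanyl groups stayed modest or within the scatter, whereas ((4-bromophenyl)sulfonyl)amino gives large steps against all three (a 15-fold lower number from compound 3 to compound 4 (1.18 log units; beyond the scatter); a 12-fold lower number from compound 2 to compound 4 (1.07 log units; beyond the scatter); a 29-fold lower number from compound 1 to compound 4 (1.46 log units; beyond the scatter)). Going by these compounds alone, compound 4 is thus the strongest inhibitor of the four, and the only one carrying this group. No measurement shown here accounts for the gain.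

The compounds shown leave open which part of the entering group counts: the bromine, the benzene ring or the sulfonyl amino link. A plain phenylsulfonylamino group, a methylsulfonylamino group or a carboxamide link to the same 4-bromophenyl ring would each separate part of this.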